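Removing the Nitro Group: What to Expect for Compound 4

This account rests on a few compounds, and the source may have more. Where it says the series, first, only, none or still open, it means among the compounds named here.

Measured so far in a functional assay on PC-3 cells (Homo sapiens) for inhibition, read by MTT assay; on this read-out higher numbers stand for weaker inhibition and lower numbers for stronger inhibition:
compound 1 `COc1c(N2CCN(C)CC2)c(F)cc2c(=O)c(C(=O)N/N=C\c3ccc([N+](=O)[O-])cc3)cn(C3CC3)c12`: 15 ug/mL
compound 2 `COc1ccc(OC)c(/C=N\NC(=O)c2cn(C3CC3)c3c(OC)c(N4CCN(C)CC4)c(F)cc3c2=O)c1`: 3 ug/mL
compound 3 `COc1c(N2CCN(C)CC2)c(F)cc2c(=O)c(C(=O)N/N=C\c3cccc(O)c3)cn(C3CC3)c12`: 3.4 ug/mL

Compound 1 gives the highest of the three numbers, and both of its neighbours lie beyond the scatter: a 5.0-fold lower number from compound 1 to compound 2 (0.70 log units; beyond the scatter) and a 4.4-fold lower number from compound 1 to compound 3 (0.64 log units; beyond the scatter). Compounds 2 and 3 sit within the scatter of each other, a 1.1-fold higher number from compound 2 to compound 3 (0.05 log units; within the scatter), so neither can be called the stronger of the two.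

Compound 4 `COc1c(N2CCN(C)CC2)c(F)cc2c(=O)c(C(=O)N/N=C\c3ccccc3)cn(C3CC3)c12` has not yet been measured. It differs from compound 1 by one change: hydrogen in place of nitro on an aromatic carbon. The two measured steps away from compound 1 both replaced the 4-nitrophenyl with another aryl group, and both brought modest drops in the number. For the measured compounds named here, the change to compound 4 is simpler, keeping the phenyl and only removing the nitro, so the only guidance is that the 4-nitrophenyl arm went with the highest number seen. A modest lowering is therefore expected in this assay, roughly in line with those two steps, though it may also come out within the scatter of compound 1.

Compound 4 is estimated at 5 ug/mL, within 2 ug/mL to 15 ug/mL, an expected step of a 3.0-fold lower number from compound 1 to compound 4 (0.48 log units; beyond the scatter).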

Compound 4, half-maximal inhibitory concentration: 16.3 ug/mL
Estimate against measurement, compound 4: 3.3-fold (0.51 log units) below; measured number outside the range, above it.
By their numbers in this assay, from the lowest: compounds 2 and 3 (each within the scatter of the next); then compounds 1 and 4 (each within the scatter of the next).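

Nitro and hydrogen cannot be told apart at this place on the ring (a 1.1-fold higher number from compound 1 to compound 4 (0.04 log units; within the scatter)), so the 4-nitrophenyl arm of compound 1 reads the same as a bare phenyl. The gap that compound 2 and compound 3 opened from compound 1 therefore also holds against the unsubstituted ring, both for hydrogen in place of hydroxy (a 4.8-fold higher number from compound 3 to compound 4 (0.68 log units; beyond the scatter)) and for phenyl in place of 2,5-dimethoxyphenyl (a 5.4-fold higher number from compound 2 to compound 4 (0.74 log units; beyond the scatter)). Among these four compounds, the lower numbers go with the rings carrying hydroxy or methoxy groups rather than with the absence of the nitro, although nothing available explains this link.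

As far as these compounds go, whether an amine or a carboxylic acid at the place held by the nitro would read like compound 1 and compound 4, or like compound 2 and compound 3, remains open. Also open is whether both methoxy groups of compound 2 are needed for its lower number, as no phenyl with a single methoxy group is among the compounds shown.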